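Cyclopentyl to pentan-3-yl on the shared core

The source may report more compounds than this note shows. Statements on the series, on what has been measured and on what is new or still open speak of the compounds shown alone.

In a functional assay on HCT-15 cells (Homo sapiens) for antiproliferative activity, read by sulforhodamine B assay (on this read-out lower numbers stand for stronger inhibition of growth and higher numbers for weaker inhibition of growth), compound 1 (`CC(C)CCCOc1cccc(O)c1C(=O)/C=C/c1ccc(O)cc1`) gives 11600 nM, and compound 3 (`O=C(/C=C/c1ccc(O)cc1)c1c(O)cccc1OCC1CCCC1`) gives 3410 nM. Compound 2 (`CC(C)=CCOc1cccc(O)c1C(=O)/C=C/c1ccc(O)cc1`) gives > 30000 nM, which is a limit and not a number. Compound 3 therefore has the lower of the two actual numbers, and the measured steps run a 3.4-fold lower number from compound 1 to compound 3 (0.53 log units; beyond the scatter) and an at least 8.7-fold lower number from compound 2 to compound 3 (0.94 log units; beyond the scatter).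

Compound 4 (`CCC(CC)COc1cccc(O)c1C(=O)/C=C/c1ccc(O)cc1`) has pentan-3-yl in place of cyclopentyl on a saturated chain carbon bound to an oxygen on an aromatic ring. For the measured compounds named here, the closest precedent is compound 1, which also has an open saturated group, so a 3.4-fold lower number from compound 1 to compound 3 (0.53 log units; beyond the scatter) is read in reverse. The unsaturated group of compound 2 is a more distant guide, with an at least 2.5-fold higher number from compound 1 to compound 2 (0.41 log units; beyond the scatter). Going by the values given here, no measured compound carries pentan-3-yl, so a modest rise toward the number of compound 1 is expected in this assay. The expected step is a 2.1-fold higher number from compound 3 to compound 4 (0.31 log units; beyond the scatter). The estimate for compound 4 is 7000 nM, with an expected range of 2800 nM to 17000 nM.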

Compound 4, concentration for 50% growth inhibition: 3420 nM
Beside the measured number, compound 4's estimate is 2.0-fold (0.31 log units) above it; the range from low to high includes it.
By their numbers in this assay, from the lowest: compounds 3 and 4 (each within the scatter of the next); then compound 1. At a limit, above all of these: compound 2.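

In this assay, pentan-3-yl in place of cyclopentyl gives a 1.0-fold higher number from compound 3 to compound 4 (0.00 log units; within the scatter), so among the groups shown, a ring is not required on this saturated chain carbon bound to an oxygen on an aromatic ring. An open saturated group alone does not set the number either, since pentan-3-yl in place of isopentyl gives a 3.4-fold lower number from compound 1 to compound 4 (0.53 log units; beyond the scatter). The remaining step, an at least 8.7-fold lower number from compound 2 to compound 4 (0.94 log units; beyond the scatter), rests on a limit for compound 2 and not on a number: the limit of > 30000 nM in this assay, at which 1 of the 4 values shown sits.

The compounds shown leave open whether cyclohexyl, a longer chain or an amine-bearing chain in this place would keep the level of compound 3 and compound 4. They also leave open whether these steps hold on any other cell line.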